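Dechlorination step in the thiosemicarbazone series

The compounds below may be only part of what the source reports. "The series", "measured", "known", "first", "only" and "open" are said of these compounds alone.

Of the compounds shown here, two have been measured in a functional assay on MDA-MB-468 cells (Homo sapiens) for cytotoxicity, read by sulforhodamine B assay, with a stated time of 48 h; a lower number here means a stronger inhibitor of growth, a higher number a weaker inhibitor of growth. Compound 1 `O=C1C(=O)N(CN2CCN(c3ccnc4cc(C(F)(F)F)ccc34)CC2)c2cccc(Cl)c21` gives 28400 nM. Compound 2 `NC(=S)N/N=C1/C(=O)N(CN2CCN(c3ccnc4cc(Cl)ccc34)CC2)c2cc(Cl)ccc21` gives 26500 nM; this is the lowest of the two numbers, but the gap to compound 1 lies within the scatter, so the two stand level. For the measured compounds named here, compound 1 and compound 2 differ in more than one place, and no step between them is drawn.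

Compound 3 `NC(=S)N/N=C1/C(=O)N(CN2CCN(c3ccnc4cc(Cl)ccc34)CC2)c2ccccc21` has not been measured. It differs from compound 2 by hydrogen in place of chloro on an aromatic carbon. Going by the values given here, no single-point step of this kind exists among the measured compounds, so nothing about its size can be read from the numbers. The expectation is a step from compound 2 to compound 3 of a 1.2-fold higher number from compound 2 to compound 3 (0.08 log units; within the scatter), that is, none beyond the scatter in either direction. Compound 3 is therefore estimated at 32000 nM, with a range from 12000 nM to 85000 nM.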

Compound 3, concentration for 50% growth inhibition: 20600 nM
Beside the measured number, compound 3's estimate is 1.6-fold (0.19 log units) above it, and the stated range covers the measured number.
By their numbers in this assay, from the lowest: compounds 3, 2 and 1 (each within the scatter of the next).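

In this assay, hydrogen in place of chloro on this aromatic carbon gives a 1.3-fold lower number from compound 2 to compound 3 (0.11 log units; within the scatter), the first single-point step available in the thiosemicarbazone series. At this one pair, the chloro is therefore not needed to keep growth inhibition at the level of the series, and its removal produces no change that can be separated from the scatter. No measurement at hand bears on why this position accepts the change.

Going by these compounds, whether a larger or different group on this carbon, such as methoxy, an amine or a carboxylic acid, would shift the number beyond the scatter remains open. For the compounds shown here, the contribution of the thiosemicarbazone itself also remains open, since compound 1 differs from the others in more than one place and no step to it can be read.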